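Same Swap, Second Core: Chlorophenyl for Benzyl Again

The source may hold more compounds than are shown below. What is called first, only, known or untested is meant among the compounds shown, and "the series" means these compounds.

Compound 1 `O=c1nc2oc(C3CC3)c(C#CC3CC3)c2cn1Cc1cn(Cc2ccccc2)nn1` gives 9720 nM in a functional assay on SW-620 cells (Homo sapiens) for antiproliferative activity, read by MTT assay, with a stated time of 72 h; a lower number here means a stronger inhibitor, a higher number a weaker inhibitor.
Compound 2 `CCCCCCC#Cc1c(CCCCCC)oc2nc(=O)n(Cc3cn(-c4ccc(Cl)cc4)nn3)cc12` gives > 100000 nM in this assay, which is a limit of the assay and not a number.
Compound 3 `CCCCCCC#Cc1c(CCCCCC)oc2nc(=O)n(Cc3cn(Cc4ccccc4)nn3)cc12` gives 32600 nM in this assay.

Among the two numbers given, compound 1 holds the lower one, and its nearest neighbour is compound 3, whose value sits a step above it that lies beyond the usual scatter. The two cores are different, and the difference between the core of compound 1 and the core of compound 3 is not broken down here.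

One change has been measured directly: from compound 3 to compound 2 the substituent on the triazole changes, (4-chlorophenyl in place of benzyl on an aromatic nitrogen), and the effect is an at least 3.0-fold higher number from compound 3 to compound 2 (0.48 log units; beyond the scatter). The size of that step is only a lower bound, because compound 2 sits at the limit of > 100000 nM in this assay, at which 1 of the 3 values shown sits.

Compound 4 `O=c1nc2oc(C3CC3)c(C#CC3CC3)c2cn1Cc1cn(-c2ccc(Cl)cc2)nn1` has not yet been measured in this assay. It arises from compound 1 by 4-chlorophenyl in place of benzyl on an aromatic nitrogen, and the place where the change is made is described in the same words as for the measured pair, so it is the same change on a different core. Going by the values given here, compound 4 is expected to be weaker than compound 1 by a 3.1-fold higher number from compound 1 to compound 4 (0.49 log units; beyond the scatter), an expectation that rests on the measured pair because an at least 3.0-fold higher number from compound 3 to compound 2 (0.48 log units; beyond the scatter) points in that direction, though the single measured example gives it only modest weight. The estimate for compound 4 is therefore 30000 nM, with a range from 12000 nM to 90000 nM.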

Compound 4, half-maximal inhibitory concentration: 36900 nM
Compound 4: middle estimate off by 1.2-fold (0.09 log units), on the low side; the range from low to high includes it.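

In this assay, putting 4-chlorophenyl in place of benzyl on an aromatic nitrogen of the triazole gives a 3.8-fold higher number from compound 1 to compound 4 (0.58 log units; beyond the scatter), and this time the step has a real number at both ends. The change thus moves the number in the same direction on both cores, and each step lies beyond the scatter: the same change on two cores in this assay, an at least 3.0-fold higher number (0.48 log units; beyond the scatter) from compound 3 to compound 2 and a 3.8-fold higher number (0.58 log units; beyond the scatter) from compound 1 to compound 4; the limit leaves it open whether they differ. Compound 2 stands at > 100000 nM, which is a limit of the assay and not a number, so the series does not show whether the change costs the same on each core, and two pairs make no rule for any further core.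

The compounds shown leave open whether the higher number follows from losing the benzyl link or from gaining the chlorine, a question that a plain phenyl or a 4-chlorobenzyl group in the same place would separate. They also leave open how an amine or a carboxylic acid would read there, and how much each of the two groups that set the cores apart contributes alone, since no pair shown changes only a cyclopropyl group for a longer chain.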